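Naphthyl in Place of Bromo: Vero Cell Cytotoxicity

The source may hold more compounds than are shown below. What is called first, only, known or untested is meant among the compounds shown, and "the series" means these compounds.

Compound 1 `COc1ccc2c(c1)[C@@H](O)CN(C)C2` sits at the limit of > 100000 nM in this assay, at which 1 of the 3 values shown sits, in an ADME assay on Vero cells (Chlorocebus sabaeus) for cytotoxicity, read by sulforhodamine B assay, with a stated time of 72 h (on this read-out higher numbers stand for weaker inhibition and lower numbers for stronger inhibition), giving > 100000 nM. Compound 2 `CN1Cc2ccc(OCC3CCCCC3)cc2[C@@H](O)C1` gives 65600 nM. Compound 3 `CN1Cc2ccc(OCc3ccc(Br)cc3)cc2[C@@H](O)C1` gives 37000 nM.

Of the two numbers, compound 3 has the lowest, with compound 2 nearest, though a 1.8-fold lower number from compound 2 to compound 3 (0.25 log units; within the scatter) lies within the scatter. Compound 4 `CN1Cc2ccc(OCc3ccc(-c4ccc5ccccc5c4)cc3)cc2[C@@H](O)C1` differs from compound 3 by naphthalen-2-yl in place of bromo on an aromatic carbon. Going by the values given here, the steps that bear on it are an at least 1.5-fold lower number from compound 1 to compound 2 (0.18 log units; that floor lies within the scatter), an at least 2.7-fold lower number from compound 1 to compound 3 (0.43 log units; beyond the scatter) and a 1.8-fold lower number from compound 2 to compound 3 (0.25 log units; within the scatter): each growth of the ether substituent has lowered the number, only the last step beyond the scatter. A further, larger aromatic addition is therefore expected to give a modest decrease, a 1.9-fold lower number from compound 3 to compound 4 (0.27 log units; within the scatter). Compound 4 is estimated at 20000 nM, between 6000 nM and 60000 nM.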

Compound 4, half-maximal inhibitory concentration: 310 nM
The estimate for compound 4 lay 65-fold (1.81 log units) above the measured number; measured number below the stated range.
By their numbers in this assay, from the lowest: compound 4; then compounds 3 and 2 (each within the scatter of the next). At a limit, above all of these: compound 1.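

In this assay naphthalen-2-yl in place of bromo gives a 120-fold lower number from compound 3 to compound 4 (2.08 log units; beyond the scatter) and so shows that this aromatic carbon, para to a large group, can move the number far more than the exchange of ether substituents did, which gave a 1.8-fold lower number from compound 2 to compound 3 (0.25 log units; within the scatter) and stayed within the scatter. Nothing measured among these compounds accounts for the size of this step.

The compounds shown carry only bromo and naphthalen-2-yl at this carbon. They leave open whether a phenyl group, with one ring in place of two, would give a similarly low number, and what an amine or a carboxylic acid there would do.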